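The compounds below may be only part of what the source reports. "The series", "measured", "known", "first", "only" and "open" are said of these compounds alone.

Working notes on the series, read in a physicochemical assay for pharmacokinetics; a lower number here means that the compound disappears faster, a higher number that the compound lasts longer. Compound 1 (`CC(NC(=O)N1C(=O)c2ccccc2S1(=O)=O)c1ccccc1`) gives 0.663 h, compound 2 (`O=C(NCc1ccccc1Br)N1C(=O)c2ccccc2S1(=O)=O`) gives 0.253 h and compound 3 (`COc1cccc(CNC(=O)N2C(=O)c3ccccc3S2(=O)=O)c1`) gives 0.523 h. Compound 3 thus lies within the scatter of compound 1 and beyond the scatter above compound 2. Compound 4 (`O=C(NCc1ccccc1)N1C(=O)c2ccccc2S1(=O)=O`) carries hydrogen in place of methoxy on an aromatic carbon. Among the measured compounds shown here, the only measured step bearing on this is the modest 2.1-fold higher number from compound 2 to compound 3 (0.32 log units; beyond the scatter), which also alters the substituted phenyl. For the measured compounds named here, no measured step removes methoxy alone, so no step beyond the scatter is expected in this assay, and neither direction is favoured. The expected change is a 1.2-fold lower number from compound 3 to compound 4 (0.07 log units; within the scatter). The estimate for compound 4 is 0.45 h, with an expected range of 0.25 h to 0.8 h.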

Compound 4, half-life: 1.02 h
Compound 4: the middle estimate sits 2.3-fold (0.36 log units) below what was measured; measured number above the stated range.
By their numbers in this assay, from the lowest: compound 2; then compounds 3, 1 and 4 (each within the scatter of the next).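

In this assay, only the loss of bromo gives a step beyond the scatter (a 4.0-fold higher number from compound 2 to compound 4 (0.61 log units; beyond the scatter)), while the loss of methoxy (a 2.0-fold higher number from compound 3 to compound 4 (0.29 log units; within the scatter)) and the loss of the chain methyl (a 1.5-fold higher number from compound 1 to compound 4 (0.19 log units; within the scatter)) both stay within it. Hydrogen and methoxy on this aromatic carbon therefore cannot be told apart by half-life, despite the larger estimated gap between neither group being expected. No supporting measurement explains any of these steps.
On these data alone, whether a hydroxyl or an amine on this aromatic carbon would give a step beyond the scatter stays open.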